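Removing the trifluoromethyl from the aryl group of compound 2

A few compounds are considered here, and "the series" means these few. Any claim that something is new, unique, unknown or untested is made for them only; others in the source may bear on it.

The series shares one core carrying a six-carbon chain to a piperazine with an aryl group on the far nitrogen. Compound 1 `O=C1c2ccccc2S(=O)(=O)N1CCCCCCN1CCN(c2cccc(Cl)c2)CC1` gives 233 nM in an ADME assay on HEK293 cells for displacement of a labelled ligand from 5-hydroxytryptamine receptor 7 (Homo sapiens), read by radioligand binding, with a stated time of 1 h; a lower number here means a stronger inhibitor, a higher number a weaker inhibitor. For the measured compounds named here, compound 2 `O=C1c2ccccc2S(=O)(=O)N1CCCCCCN1CCN(c2ccccc2C(F)(F)F)CC1` gives 195 nM in this assay; the step of a 1.2-fold lower number from compound 1 to compound 2 (0.08 log units; within the scatter) is the only measured step so far. Compound 2 thus holds the lowest of the two numbers, but its gap to compound 1 is within the scatter, so no order between them can be stated.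

Compound 3 `O=C1c2ccccc2S(=O)(=O)N1CCCCCCN1CCN(c2ccccc2)CC1` is unmeasured. It differs from compound 2 by hydrogen in place of trifluoromethyl on an aromatic carbon, that is, 2-(trifluoromethyl)phenyl to phenyl. Going by the values given here, no measured step concerns the trifluoromethyl itself; the one step available, a 1.2-fold lower number from compound 1 to compound 2 (0.08 log units; within the scatter), shows that exchanging one substituted aryl group for another left the number within the scatter. On that basis the removal of the group is expected to give a step of a 1.6-fold higher number from compound 2 to compound 3 (0.22 log units; within the scatter) in this assay, a modest weakening that may itself stay within the scatter. Compound 3 is therefore estimated at 320 nM in this assay, with a range from 120 nM to 850 nM.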

Compound 3, inhibition constant: 192 nM
Compound 3: the middle estimate sits 1.7-fold (0.22 log units) above what was measured, within the range that was stated.
By their numbers in this assay, from the lowest: compounds 3, 2 and 1 (each within the scatter of the next).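

With hydrogen in place of trifluoromethyl on an aromatic carbon, the step in this assay is a 1.0-fold lower number from compound 2 to compound 3 (0.01 log units; within the scatter), so at this position the phenyl of compound 3 cannot be told apart from the 2-(trifluoromethyl)phenyl of compound 2. The step for hydrogen in place of chloro is a 1.2-fold lower number from compound 1 to compound 3 (0.08 log units; within the scatter), so compound 3 also cannot be told apart from compound 1, and the series now has an unsubstituted aryl reference against which neither substituted aryl group stands out. No supporting measurement bears on the reason for this result.

On these data alone, what a methoxy or an amine on the aromatic ring would give remains open, as does whether trifluoromethyl and chloro would still read alike on the same aromatic carbon. All the compounds shown carry the six-carbon chain and the same core, so how the number responds to a shorter or longer chain, or to a change in the core, also stays open.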